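Tolerance of the sulfamoyl anilide in the MT4 series

The compounds below may be only part of what the source reports. "The series", "measured", "known", "first", "only" and "open" are said of these compounds alone.

In an ADME assay on MT4 cells (Homo sapiens) for cytotoxicity, read by MTT assay, with a stated time of 5 days (a higher number here means that more compound is tolerated, a lower number that less compound is tolerated), compound 1 (`Cc1ccc(NC(=O)CSc2nc3ccccc3n2S(=O)(=O)c2cc(C)cc(C)c2)cc1`) gives 2970 nM, the lower of the two numbers available. Compound 2 (`COC(=O)c1ccc(NC(=O)COc2nc3ccccc3n2S(=O)(=O)c2cc(C)cc(C)c2)c(Cl)c1`) gives 119000 nM, a gap well beyond the scatter. Compound 1 therefore sits at the less tolerated end of this small set.

The next compound to read is compound 3 (`Cc1cc(C)cc(S(=O)(=O)n2c(SCC(=O)Nc3ccc(S(N)(=O)=O)cc3Cl)nc3ccccc32)c1`). It has 2-chloro-4-sulfamoylphenyl in place of 4-methylphenyl on an amide-type nitrogen. Each group holds one six-membered aromatic ring of carbon only, and neither carries a net charge.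

Going by the values given here, no measured pair isolates this change, so the expectation is loose. It rests on two anchors only: compound 1 at 2970 nM as the lower reference and compound 2 at 119000 nM as the upper one. A move towards more compound tolerated, beyond the scatter, seems more likely than no change, with the result landing between those two anchors. The estimated step is a 6.7-fold higher number from compound 1 to compound 3 (0.83 log units; beyond the scatter). For compound 3 the expected value in this assay is 20000 nM, with an estimated range of 5000 nM to 100000 nM.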

Compound 3, half-maximal cytotoxic concentration: 25600 nM
Compound 3: the middle estimate sits 1.3-fold (0.11 log units) below what was measured; measured number inside the range.
By their numbers in this assay, from the lowest: compound 1; then compound 3; then compound 2.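

In this assay the group on the amide-type nitrogen now has its first readable single change: 2-chloro-4-sulfamoylphenyl in place of 4-methylphenyl gives an 8.6-fold higher number from compound 1 to compound 3 (0.94 log units; beyond the scatter) with the rest of compound 1 unchanged, so this position can shift the tolerated concentration beyond the scatter. The entering group brings a chlorine and a sulfamoyl group together, and it has 1 hydrogen-bond donor and 2 hydrogen-bond acceptors where 4-methylphenyl has none, so this single step cannot divide the shift between those two pieces. Nothing on hand accounts for the higher number.

As far as these compounds go, it remains open whether the chlorine or the sulfamoyl group carries most of the step, and whether the same exchange would read alike on the core of compound 2. From the compounds shown here alone, it is also open whether a carboxylic acid or an amine in place of the sulfamoyl group would shift the number in the same direction and by a similar size.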